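A few compounds are considered here, and "the series" means these few. Any claim that something is new, unique, unknown or untested is made for them only; others in the source may bear on it.

Measured so far:
Compound 1, `COc1ccc(NC(=O)[C@@H]2CC=C(CCC=C(C)C)C[C@H]2c2ccccc2)cc1`: in an assay on isolated protein for inhibition of Apoptosis regulator Bcl-2 (Homo sapiens), read by fluorescence polarization, with stated times of 5 min and 10 min (on this read-out higher numbers stand for weaker inhibition and lower numbers for stronger inhibition), compound 1 gives a limit of > 23000 nM.
Compound 2, `CONC(=O)[C@@H]1CC=C(CCC=C(C)C)C[C@H]1c1ccccc1`: in this assay compound 2 gives 2700 nM.
Compound 3, `COc1ccc(NC(=O)[C@H]2CC=C(CCC=C(C)C)C[C@@H]2c2ccccc2)cc1`: in this assay compound 3 gives a limit of > 23000 nM.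

The change from compound 1 to compound 2 is methoxy in place of 4-methoxyphenyl on an amide-type nitrogen. The step is an at least 8.5-fold lower number from compound 1 to compound 2 (0.93 log units; beyond the scatter), and it can only be read as a bound because of the limit of > 23000 nM in this assay, at which 2 of the 3 values shown sit. Compounds 1 and 3 are related by the two compounds have the same atoms and bonds and differ only in configuration as drawn: 2 of 2 stereo elements differ (all stereocentres are inverted: mirror images); a stereocentre at a saturated ring carbon is drawn R in compound 1 and S in compound 3; a stereocentre at a saturated ring carbon is drawn R in compound 1 and S in compound 3; the step is a step that the two limits leave unreadable from compound 1 to compound 3, and its size cannot be read because of the limit of > 23000 nM in this assay, at which 2 of the 3 values shown sit.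

Compound 4, `CONC(=O)[C@H]1CC=C(CCC=C(C)C)C[C@@H]1c1ccccc1`, differs from compound 3 by methoxy in place of 4-methoxyphenyl on an amide-type nitrogen, the same change seen from compound 1 to compound 2. Compound 4 is therefore the mirror image of compound 2, a relation like that between compounds 1 and 3 in the fact that compounds 1 and 3 differ only in the configuration as drawn. He expects the step from compound 3 to compound 4 to be an at least 2.8-fold lower number from compound 3 to compound 4 (0.45 log units; beyond the scatter), resting on compound 2 at 2700 nM, while allowing that the mirror image may not match it. His estimate for compound 4 is 8000 nM, between 1500 nM and 40000 nM.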

Compound 4, inhibition constant: 2400 nM
Compound 4: middle estimate off by 3.3-fold (0.52 log units), on the high side, and the stated range covers the measured number.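

In this assay, methoxy in place of 4-methoxyphenyl gives an at least 9.5-fold lower number from compound 3 to compound 4 (0.98 log units; beyond the scatter), so the change points the same way on both mirror-image cores: the same change on two cores in this assay, an at least 8.5-fold lower number (0.93 log units; beyond the scatter) from compound 1 to compound 2 and an at least 9.5-fold lower number (0.98 log units; beyond the scatter) from compound 3 to compound 4; the limit leaves it open whether they differ. The two methoxy compounds show a 1.1-fold lower number from compound 2 to compound 4 (0.05 log units; within the scatter), so inverting both stereocentres has no readable effect on this pair: the fact that compounds 2 and 4 differ only in the configuration as drawn. Compound 1 and compound 3 each stand at a limit, so the step between them cannot be read and the size of the change on each core is known only as a bound: the limit of > 23000 nM in this assay, at which 2 of the 4 values shown sit.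

The compounds shown leave open whether a hydroxy or ethoxy group on the amide-type nitrogen would behave like methoxy. They also leave open whether a simple amine there would do the same.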